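This account rests on a few compounds, and the source may have more. Where it says the series, first, only, none or still open, it means among the compounds named here.

In an ADME assay on microsomes from liver (Mus musculus, strain CD-1) for metabolic stability, read by HPLC, using NADPH, with a stated time of 30 min, in the presence of a further agent that is not named here (on this read-out lower numbers stand for slow clearance and higher numbers for fast clearance), compound 1 `NC(=O)c1sccc1OCCc1ccccc1` gives 26 mL.min-1.g-1. Compound 2 `NC(=O)c1sc(N2CCCCC2)cc1OCCc1ccccc1`, which carries piperidin-1-yl in place of a hydrogen on an aromatic carbon, gives 42 mL.min-1.g-1. Compound 2 has the higher of these two numbers, but they lie within the usual scatter of each other, so the data do not separate the two compounds.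

Compound 3 `NC(=O)c1sc(N2CCOCC2=O)cc1OCCc1ccccc1` has 3-oxomorpholin-4-yl in place of piperidin-1-yl on the same aromatic carbon, next to the ring sulfur: 3-oxomorpholin-4-yl in place of piperidin-1-yl on an aromatic carbon. Within the data shown here, only one measured step bears on this change, a 1.6-fold higher number from compound 1 to compound 2 (0.21 log units; within the scatter), and it involves the piperidin-1-yl group that now leaves. Among the measured compounds shown here, that step stays within the scatter, and no compound with 3-oxomorpholin-4-yl has yet been measured. A small effect is therefore the most reasonable expectation in this assay, with no firm direction and a wide range. The expected change is a 1.4-fold lower number from compound 2 to compound 3 (0.15 log units; within the scatter), which is no step beyond the scatter. Compound 3 is estimated at 30 mL.min-1.g-1, with an expected range from 13 mL.min-1.g-1 to 65 mL.min-1.g-1.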

Compound 3, intrinsic clearance in microsomes: 7 mL.min-1.g-1
The estimate for compound 3 lay 4.3-fold (0.63 log units) above the measured number, and the stated range ends above it.
By their numbers in this assay, from the lowest: compound 3; then compounds 1 and 2 (each within the scatter of the next).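

In this assay the aromatic carbon next to the ring sulfur proves sensitive to what it carries: 3-oxomorpholin-4-yl in place of piperidin-1-yl gives a 6.0-fold lower number from compound 2 to compound 3 (0.78 log units; beyond the scatter) while the earlier change at this carbon, from hydrogen to piperidin-1-yl, stayed within the scatter. Measured against the compound with only hydrogen there, 3-oxomorpholin-4-yl gives a 3.7-fold lower number from compound 1 to compound 3 (0.57 log units; beyond the scatter) and so the lower number does not depend on which of the two earlier compounds serves as the reference. Piperidin-1-yl and 3-oxomorpholin-4-yl are both six-membered non-aromatic rings on the same carbon, so having such a ring at this position does not by itself bring the number down, and the difference must lie in what 3-oxomorpholin-4-yl adds to the ring.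

That group brings a ring oxygen and a carbonyl together, so the compounds shown cannot say which of the two matters; morpholin-4-yl, with the oxygen alone, and 2-oxopiperidin-1-yl, with the carbonyl alone, would separate them. Nothing measured alongside these numbers explains the drop.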